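Amide variation on the shared core: dinitrile to aspartate

This account rests on a few compounds, and the source may have more. Where it says the series, first, only, none or still open, it means among the compounds named here.

Measured in a functional assay on Caco-2 cells (Homo sapiens) for antiproliferative activity, read by MTT assay, with a stated time of 48 h; on this read-out lower numbers stand for stronger inhibition and higher numbers for weaker inhibition:
Compound 1 `CCn1c(C(=O)NCCCN(C)C)ccc1C(CC)(CC)c1ccc(OCCC(O)(CC)CC)c(C)c1` gives 490 nM.
Compound 2 `CCn1c(C(=O)N(CCC#N)CCC#N)ccc1C(CC)(CC)c1ccc(OCCC(O)(CC)CC)c(C)c1` gives only a limit, > 50000 nM, which is the limit of > 50000 nM in this assay, at which 1 of the 3 values shown sits.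
Compound 3 `CCn1c(C(=O)N(C)CC(=O)O)ccc1C(CC)(CC)c1ccc(OCCC(O)(CC)CC)c(C)c1` gives 2740 nM.

Compound 2 thus stands at the weak end of the set, with no number of its own. Compound 4 `CCn1c(C(=O)NC(CC(=O)O)C(=O)OC)ccc1C(CC)(CC)c1ccc(OCCC(O)(CC)CC)c(C)c1` is the next amide: a group of 10 heavy atoms (5 carbon, 1 nitrogen, 4 oxygen; no ring) in place of a group of 9 heavy atoms (6 carbon, 3 nitrogen; no ring), on a carbonyl carbon. Among the measured compounds shown here, the steps that bear on this change are an at least 100-fold higher number from compound 1 to compound 2 (2.00 log units; beyond the scatter) and an at least 18-fold lower number from compound 2 to compound 3 (1.26 log units; beyond the scatter), both large; compound 3, which also carries an acid, sits behind compound 1 by a 5.6-fold higher number from compound 1 to compound 3 (0.75 log units; beyond the scatter). Compound 4 combines an acid as in compound 3 with an amide hydrogen as in compound 1. The step of an at least 16-fold lower number from compound 2 to compound 4 (1.22 log units; beyond the scatter) is expected to be large and downward. Compound 4 is estimated at 3000 nM, within a range of 700 nM to 20000 nM.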

Compound 4, half-maximal inhibitory concentration: 25200 nM
The estimate for compound 4 lay 8.4-fold (0.92 log units) below the measured number; the measured number lies above the stated range.
By their numbers in this assay, from the lowest: compound 1; then compound 3; then compound 4. At a limit, above all of these: compound 2.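

Keeping the amide hydrogen does not hold the number: a group of 9 heavy atoms (5 carbon, 4 oxygen; no ring) in place of a group of 6 heavy atoms (5 carbon, 1 nitrogen; no ring), on an amide-type nitrogen, gives the large step of a 51-fold higher number from compound 1 to compound 4 (1.71 log units; beyond the scatter). Among the two acid-bearing amides, the group with the amide hydrogen and methyl ester also gives the weaker number, with a 9.2-fold higher number from compound 3 to compound 4 (0.96 log units; beyond the scatter). The step of an at least 1.9-fold lower number from compound 2 to compound 4 (0.29 log units; that floor lies within the scatter) is only a floor, and that floor lies within the scatter. Compound 2 gives only a limit: the limit of > 50000 nM in this assay, at which 1 of the 4 values shown sits.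

The compounds shown leave open whether the loss in compound 4 follows the methyl ester or the free carboxylic acid. They also leave open whether a morpholine amide or a primary amide would sit nearer compound 1.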